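The compounds below may be only part of what the source reports. "The series", "measured", "known", "first", "only" and "open" are said of these compounds alone.

Measured so far in a functional assay on SW 1116 cells (Homo sapiens) for cytotoxicity, read by MTT assay, with a stated time of 48 h; on this read-out higher numbers stand for weaker inhibition and lower numbers for stronger inhibition:
compound 1, `O=C(CSc1nnc(-c2ccncc2)o1)N/N=C/c1ccc(O)cc1`, gives 12200 nM
compound 2, `Cc1ccc(/C=N/NC(=O)CSc2nnc(-c3ccncc3)o2)cc1`, gives 16800 nM

Among the compounds with values here, compound 2 has the higher of the two numbers, but its only neighbour is compound 1, and a 1.4-fold higher number from compound 1 to compound 2 (0.14 log units; within the scatter), so the two compounds cannot be told apart on this read-out. Compound 3, `O=C(CSc1nnc(-c2ccncc2)o1)N/N=C/c1ccccc1[N+](=O)[O-]`, has not been measured. It differs from compound 2 in one place: 2-nitrophenyl in place of 4-methylphenyl on a carbon with a double bond to nitrogen. Within the data shown here, the single measured step concerns a different exchange on the group that is replaced here, a methyl in place of a hydroxy, and it stayed within the scatter. Among the measured compounds shown here, no measured step bears directly on swapping a 4-methylphenyl for a 2-nitrophenyl, so the expectation rests only on the fact that the one change tried so far moved the number little. Compound 3 is therefore expected to give about 14000 nM in this assay, within a range from 4000 nM to 50000 nM. This estimate means a step of a 1.2-fold lower number from compound 2 to compound 3 (0.08 log units; within the scatter), not beyond the scatter.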

Compound 3, half-maximal inhibitory concentration: 30700 nM
Compound 3: the middle estimate sits 2.2-fold (0.34 log units) below what was measured; low and high end bracket the measured number.
By their numbers in this assay, from the lowest: compounds 1, 2 and 3 (each within the scatter of the next, the first and the last beyond it).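

In this assay, 2-nitrophenyl in place of 4-methylphenyl gives a 1.8-fold higher number from compound 2 to compound 3 (0.26 log units; within the scatter), so on its own this exchange cannot be told apart from repeat variation. Within the data shown here, the same 2-nitrophenyl in place of the 4-hydroxyphenyl gives a 2.5-fold higher number from compound 1 to compound 3 (0.40 log units; beyond the scatter), the first step at this carbon with a double bond to nitrogen to clear the scatter, which shows that the number can respond to the aromatic group here, though only modestly. Nothing available explains this step.

The step to compound 3 changes both the group on the ring and where it sits, and the compounds shown do not separate the two. Also open, from the compounds shown here alone, is how a phenyl ring carrying an amine or a carboxylic acid, or a plain phenyl ring, would read at this carbon.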